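Moving from Trifluoromethyl to Dichloro on the Urea Aryl

The compounds below may be only part of what the source reports. "The series", "measured", "known", "first", "only" and "open" are said of these compounds alone.

The series shares one core, shown in compound 1 `COc1cc2cc(Oc3ccc(NC(=O)Nc4ccc(C(F)(F)F)cc4)cc3)c(C)nc2cc1OC` and compound 2 `COc1cc2cc(Oc3ccc(NC(=O)Nc4cccc(C(F)(F)F)c4)cc3)c(C)nc2cc1OC`, which differ only in the aryl group on the urea nitrogen. In a functional assay on SF-539 cells (Homo sapiens) for inhibition, read by sulforhodamine B assay, with a stated time of 48 h, tested at 10 uM (on this read-out lower numbers stand for a stronger effect and higher numbers for a weaker effect at the one concentration tested), compound 1 gives 96.9%, while compound 2 gives 11.7%, the lowest of the two numbers and thus the stronger effect at the single concentration tested. Within the data shown here, the one step between the measured compounds, a number 85.2 percentage points lower from compound 1 to compound 2 (beyond the scatter), shows that the read-out reacts strongly to where the substituent sits on that aryl group.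

Compound 3 `COc1cc2cc(Oc3ccc(NC(=O)Nc4ccc(Cl)c(Cl)c4)cc3)c(C)nc2cc1OC` has not yet been measured. It differs from compound 2 as follows: 3,4-dichlorophenyl in place of 3-(trifluoromethyl)phenyl on an amide-type nitrogen. Among the measured compounds shown here, no measured step follows this exact change, so only the sensitivity seen between compound 1 and compound 2 can guide an expectation. Because the step of a number 85.2 percentage points lower from compound 1 to compound 2 (beyond the scatter) was so large, a sizeable shift in either direction is plausible, and the estimate for compound 3 is therefore wide. Compound 3 is expected to give about 35%, between 5% and 85%, which would mean a step of a number 23.3 percentage points higher from compound 2 to compound 3 (beyond the scatter).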

Compound 3, a percentage reported as activity, at one concentration (the size of the read-out at that concentration, not a potency): 38.5%
Compound 3: the middle estimate sits 3.5 percentage points below what was measured; the range from low to high includes it.
By their numbers in this assay, from the lowest: compound 2; then compound 3; then compound 1.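

Replacing 3-(trifluoromethyl)phenyl with 3,4-dichlorophenyl on the amide-type nitrogen gives a number 26.8 percentage points higher from compound 2 to compound 3 (beyond the scatter) in this assay, so a second aryl group retains a clear effect at this position without reaching the level of the 3-(trifluoromethyl)phenyl group. Set against 4-(trifluoromethyl)phenyl, the same group gives a number 58.4 percentage points lower from compound 1 to compound 3 (beyond the scatter), which shows that the weak read-out of that group is not shared by every aryl group whose name carries a substituent at 4, since 3,4-dichlorophenyl carries one too. The data offer no measured property that would explain why these three aryl groups separate as they do.

The compounds shown do not separate the contribution of each chlorine, so it remains open how 3-chlorophenyl or 4-chlorophenyl alone would read compared with the 3,4-dichlorophenyl group. From the compounds shown here alone, it also remains open how this position would respond to an aryl group bearing something quite different from a halogen or trifluoromethyl, such as a methoxy group, an amine or a carboxylic acid, and whether the order seen here would hold in other cell lines.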